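Quaternary head-group swaps at the chain end

This account rests on a few compounds, and the source may have more. Where it says the series, first, only, none or still open, it means among the compounds named here.

Measured so far in an assay on LX2 cells for inhibition of COL1A1 promoter (Homo sapiens), read by a luciferase reporter, with a stated time of 24 h, tested at 50 uM; on this read-out higher numbers stand for a stronger effect at the one concentration tested and lower numbers for a weaker effect:
- compound 1 `CN(C)c1ccc2c(=O)c(C(=O)Nc3cc(F)cc(F)c3)cn(-c3ccc(OCCCCCCC[N+]45CCN(CC4)CC5)cc3Cl)c2n1`: 80%
- compound 2 `CN(C)c1ccc2c(=O)c(C(=O)Nc3cc(F)cc(F)c3)cn(-c3ccc(OCCCCCCC[N+]4(C)CCCC4)cc3Cl)c2n1`: "not active" (no number reported)
- compound 3 `CN(C)c1ccc2c(=O)c(C(=O)Nc3cc(F)cc(F)c3)cn(-c3ccc(OCCCCCCC[N+]4(C)CCCCC4)cc3Cl)c2n1`: "not active" (no number reported)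

Compound 3 stands without a single number in this assay; the entry for it is a qualitative "not active" and nothing more. Compound 2 is in the same position, also with no number. Only compound 1 carries a number, and a comparison of compound 3 with it can therefore only say that compound 1 gives a measured inhibition where compound 3 gives none reported. For the measured compounds named here, no step between measured pairs differing in one place is available in this set.

Compound 4 `CN(C)c1ccc2c(=O)c(C(=O)Nc3cc(F)cc(F)c3)cn(-c3ccc(OCCCCCCC[n+]4ccccc4)cc3Cl)c2n1` is not yet measured. It differs from compound 3 as follows: a group of 6 heavy atoms (5 carbon, 1 nitrogen; one six-membered aromatic ring with 1 hetero atom) in place of a group of 7 heavy atoms (6 carbon, 1 nitrogen; one six-membered non-aromatic ring with 1 hetero atom), on a saturated chain carbon, seven bonds along the chain from an oxygen on an aromatic ring. The change keeps the positive charge and the chain length and replaces the six-membered non-aromatic ring with one hetero atom by a six-membered aromatic ring with one hetero atom.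

Going by the values given here, with no step in hand, the size of the expected step in this assay cannot be taken from the data. Given that compound 3 is reported as "not active" (no number reported) and compound 2 as "not active" (no number reported), the expectation for compound 4 is a weak read-out, with a fair chance of another qualitative entry. Compound 4 is estimated at 25%, between 0% and 60%.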

Compound 4, a percentage reported as inhibition, at one concentration (the size of the read-out at that concentration, not a potency): "not active" (no number reported)
Compound 4 has no reported number here; the estimate stays without a comparison.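

In this assay compound 4 and compound 3 both carry only the qualitative entry "not active", so no step can be read between them. Nothing measured here bears on a cause for this result.
The compounds shown leave open whether the aromatic ring of compound 4 and the non-aromatic ring of compound 3 differ in effect at any other concentration.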